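Removing the methyl from compound 1: expected outcome

A few compounds are considered here, and "the series" means these few. Any claim that something is new, unique, unknown or untested is made for them only; others in the source may bear on it.

Compound 1 `Cc1ccc(NC(=O)Nc2nc(Nc3ccccc3)cc(Sc3c[nH]c4ccccc34)n2)cc1` gives 23500 nM in a functional assay on A549 cells (Homo sapiens) for inhibition, with a stated time of 72 h (a higher number here means a weaker inhibitor, a lower number a stronger inhibitor), the lowest of the two numbers shown, though its gap to compound 2 lies within the scatter. Compound 2 `Cc1cc(Cl)ccc1NC(=O)Nc1nc(NC2CC2)cc(Sc2c[nH]c3ccccc23)n1` gives 31500 nM in this assay. Compound 3 `O=C(Nc1ccccc1)Nc1nc(Sc2c[nH]c3ccccc23)cc(N2CCN(Cc3ccccc3)CC2)n1` in this assay returns only > 50000 nM, a limit rather than a number. One of the three results is thus (the limit of > 50000 nM in this assay, at which 1 of the 3 values shown sits). Compound 4 `O=C(Nc1ccccc1)Nc1nc(Nc2ccccc2)cc(Sc2c[nH]c3ccccc23)n1` differs from compound 1 by hydrogen in place of methyl on an aromatic carbon. For the measured compounds named here, no step between measured compounds differing in one place exists in this set, so no size of step can be read off. The expected step is a 1.1-fold higher number from compound 1 to compound 4 (0.03 log units; within the scatter), none beyond the scatter. Compound 4 is estimated at 25000 nM, between 10000 nM and 60000 nM.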

Compound 4, half-maximal inhibitory concentration: > 50000 nM
Compound 4 ended at the assay's limit; the forecaster's own chance of this, stated with the estimate: 25%; middle value at least 2.0-fold (0.30 log units) away from the limit.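

For the compounds shown here, the 4-methylphenyl to phenyl change gives the first single-place step, and it lies beyond the scatter: an at least 2.1-fold higher number from compound 1 to compound 4 (0.32 log units; beyond the scatter). The methyl on this aromatic carbon, para to a large group, therefore counts in this assay, though compound 4 gives > 50000 nM, which is a limit, so the full size of the step stays unread. Limit results now recur in the set: the limit of > 50000 nM in this assay, at which 2 of the 4 values shown sit.

As far as these compounds go, whether an ethyl group, a methoxy group or an amine at this carbon would give a lower number than compound 1 remains open. Also open, from the compounds shown here alone, is whether the methyl counts the same way with other groups elsewhere on the core.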